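The source may report more compounds than this note shows. Statements on the series, on what has been measured and on what is new or still open speak of the compounds shown alone.

Measured compounds:
compound 1, `C=C1C[C@]23C[C@@]1(O)CC[C@H]2c1cc2c(C(=O)O)coc2c(C)c1[C@@H]3C(=O)O`: > 10000 nM
compound 2, `C=C1C[C@]23C[C@@]1(O)CC[C@H]2c1cc(Br)c(O/C=C/C(=O)OC)c(C)c1[C@@H]3C(=O)OC`: > 10000 nM

In a functional assay on HCC1599 cells (Homo sapiens) for cytotoxicity, read by luminescence and CellTiter-Glo, with a stated time of 24 h (a lower number here means a stronger inhibitor, a higher number a weaker inhibitor), compound 1 reaches only a limit, > 10000 nM. In this assay compound 2 likewise reaches only a limit, > 10000 nM. Among the measured compounds shown here, both measured values therefore sit at the limit of > 10000 nM in this assay, at which 2 of the 2 values shown sit, so compound 2 cannot be placed above or below compound 1 on these numbers; it stands at the limit, and no step between measured compounds can be drawn.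

Compound 3, `C=C1C[C@]23C[C@@]1(O)CC[C@H]2c1ccc(O/C=C/C(=O)OC)c(C)c1[C@@H]3C(=O)OC`, is the next compound to be tested. It differs from compound 2 by hydrogen in place of bromo on an aromatic carbon. For the measured compounds named here, because the two values shown both sit at the limit of > 10000 nM in this assay, at which 2 of the 2 values shown sit, there is no measured step from which a direction could be read. Going by the values given here, with no measured step to lean on, the step from compound 2 to compound 3 in this assay is expected to be none beyond the usual scatter, and compound 3 is expected to remain at the limit as well. For compound 3 the estimate in this assay is 15000 nM, with a range from 5000 nM to 50000 nM, corresponding to an expected step that the limit leaves unreadable from compound 2 to compound 3.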

Compound 3, half-maximal inhibitory concentration: > 10000 nM
Compound 3 was reported as a limit; the forecaster's own chance of this, stated with the estimate: 80%; the middle value lies beyond the limit too.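

Compound 3, like compound 2, reaches only a limit in this assay, so no step can be read from compound 2 to compound 3 for hydrogen in place of bromo on an aromatic carbon: the limit of > 10000 nM in this assay, at which 3 of the 3 values shown sit.

The compounds shown leave open how far each lies beyond that limit, and so whether this exchange changes the cytotoxicity at all.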